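The compounds below may be only part of what the source reports. "The series", "measured", "known", "first", "only" and "open" are said of these compounds alone.

In an ADME assay on MCF7-DOX cells (Homo sapiens) for cytotoxicity, read by MTT assay, with a stated time of 48 h (on this read-out lower numbers stand for stronger inhibition and higher numbers for weaker inhibition), compound 1 `COc1cc(OC)c(C(=O)/C=C/c2cccc(Cl)c2)c(O)c1CC=C(C)C` gives 59500 nM and compound 2 `COc1cc(O)c(C(=O)/C=C/c2ccc(N3CCN(C(=O)OC(C)(C)C)CC3)cc2)c(OC)c1` gives 47300 nM. For the measured compounds named here, these two values lie within the usual scatter of each other, so compound 1 sits level with the only other measured compound. Compound 3 `COc1cc(OC)c(C(=O)/C=C/c2ccc(F)cc2)c(O)c1CC=C(C)C` keeps the core of compound 1 and changes one group: 4-fluorophenyl in place of 3-chlorophenyl on a double-bonded chain carbon bound to a double-bonded chain carbon. In words, 4-fluorophenyl stands in place of 3-chlorophenyl on a double-bonded chain carbon bound to a double-bonded chain carbon. Going by the values given here, compound 1 and compound 2 differ in more than one place, so no measured pair shows what such a swap does in this assay. The nearest guide is compound 1 itself, at 59500 nM. The estimated step of a 1.2-fold lower number from compound 1 to compound 3 (0.08 log units; within the scatter) is expected to stay within the scatter, with no clear direction. For compound 3 the expected value is 50000 nM, with an estimated range of 22000 nM to 100000 nM.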

Compound 3, half-maximal inhibitory concentration: 53700 nM
Estimate against measurement, compound 3: 1.1-fold (0.03 log units) below; low and high end bracket the measured number.
By their numbers in this assay, from the lowest: compounds 2, 3 and 1 (each within the scatter of the next).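

For the compounds shown here, compound 1 and compound 3 form the first measured pair that differs in one place, and in this assay putting 4-fluorophenyl in place of 3-chlorophenyl gives a 1.1-fold lower number from compound 1 to compound 3 (0.04 log units; within the scatter) and so no readable change. On a double-bonded chain carbon bound to a double-bonded chain carbon, these two halogen-bearing phenyl groups therefore read alike, even though the swap alters both the halogen and its place on the ring. Nothing available offers an explanation for this outcome.

Going by these compounds, it remains open whether 4-chlorophenyl or 3-fluorophenyl, which would separate those two alterations, or plain phenyl would read the same way in this assay at this place. Also open, on these data alone, is what a phenyl ring carrying an amine or a carboxylic acid would do there.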